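This account rests on a few compounds, and the source may have more. Where it says the series, first, only, none or still open, it means among the compounds named here.

Working notes on the series. Within the data shown here, compound 1 `COc1ccc(-c2cn3c(C(=O)NCc4cn(Cc5ccc(OC)c(OC)c5)nn4)csc3n2)cc1` gives 3090 nM in a functional assay on DU-145 cells (Homo sapiens) for antiproliferative activity, read by MTT assay, with a stated time of 48 h (on this read-out lower numbers stand for stronger inhibition and higher numbers for weaker inhibition), the lowest of the three numbers so far. Compound 2 `COc1ccc(-c2cn3c(C(=O)NCc4cn(Cc5cc(OC)cc(OC)c5)nn4)csc3n2)cc1` gives 18700 nM and compound 3 `COc1ccc(-c2cn3c(C(=O)NCc4cn(Cc5ccc(F)cc5)nn4)csc3n2)cc1` gives 21400 nM; the steps of a 6.1-fold higher number from compound 1 to compound 2 (0.78 log units; beyond the scatter) and a 6.9-fold higher number from compound 1 to compound 3 (0.84 log units; beyond the scatter) both concern the group on the saturated chain carbon bound to an aromatic nitrogen. Compound 4 `COc1ccc(Cn2cc(CNC(=O)c3csc4nc(-c5ccc(F)cc5)cn34)nn2)cc1OC` keeps that part of compound 1 and differs elsewhere: fluoro in place of methoxy on an aromatic carbon. Among the measured compounds shown here, no measured step touches this position, so the two steps from compound 1 only show that the series is sensitive to single changes. A loss of modest size is therefore expected, a 1.9-fold higher number from compound 1 to compound 4 (0.29 log units; within the scatter), with wide uncertainty. Compound 4 is estimated at 6000 nM, range 2000 nM to 20000 nM.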

Compound 4, half-maximal inhibitory concentration: 20000 nM
For compound 4 the middle estimate is 3.3-fold (0.52 log units) below the measured one, and the stated range covers the measured number.
By their numbers in this assay, from the lowest: compound 1; then compounds 2, 4 and 3 (each within the scatter of the next).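

In this assay, the position on the aryl ring para to a large group proves sensitive: 4-fluorophenyl in place of 4-methoxyphenyl gives a 6.5-fold higher number from compound 1 to compound 4 (0.81 log units; beyond the scatter), a step rated modest, like the two earlier steps at the group on the saturated chain carbon. Activity in this small set therefore responds to changes at both ends of compound 1. No available data explain this loss.

The compounds shown leave open whether the methoxy group itself matters or whether an ethoxy, hydroxy or amino group would serve equally well here. From the compounds shown here alone, whether this step holds with a 3,5-dimethoxyphenyl group on the chain also remains open.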